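The compounds below may be only part of what the source reports. "The series", "measured", "known", "first", "only" and "open" are said of these compounds alone.

Measured so far in a functional assay on SEM cells (Homo sapiens) for inhibition, read by MTT assay, with a stated time of 72 h; on this read-out higher numbers stand for weaker inhibition and lower numbers for stronger inhibition:
- Compound 1 `C=C(Br)C(=O)Nc1cccc(/C=C/C(=O)Nc2ccc(OC)cc2)c1`: 70 nM
- Compound 2 `C=C(Br)C(=O)Nc1cccc(/C=C/C(=O)Nc2ccc(OCC)cc2)c1`: 180 nM
- Compound 3 `C=C(Br)C(=O)Nc1cccc(/C=C/C(=O)Nc2ccc(SC(F)(F)F)cc2)c1`: 12700 nM

Compound 1 has the lowest number of the three, and both other compounds lie beyond the scatter from it. The next compound to be tested is compound 4 `C=C(Br)C(=O)Nc1cccc(/C=C/C(=O)Nc2ccc(OC)c(OC)c2)c1`. It keeps all of compound 1 and gains one group, methoxy in place of hydrogen on an aromatic carbon, ortho to a methoxy group (methoxy in place of hydrogen on an aromatic carbon).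

Two measured steps from compound 1 change the existing methoxy group. Replacing methoxy with ethoxy gave a 2.6-fold higher number from compound 1 to compound 2 (0.41 log units; beyond the scatter). Replacing methoxy with (trifluoromethyl)sulfanyl gave a 180-fold higher number from compound 1 to compound 3 (2.26 log units; beyond the scatter). Compound 4 keeps its methoxy group, so the modest ethoxy step is the closer guide, while the large step serves as a warning. Among the compounds with values here, neither is a direct precedent, since no measured compound carries a second group on that aromatic ring. Both steps raised the number, so a modest rise is expected in this assay, though a result within the scatter remains possible. The expected change is a 2.6-fold higher number from compound 1 to compound 4 (0.41 log units; beyond the scatter). Compound 4 is estimated at 180 nM, with an expected range of 50 nM to 800 nM.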

Compound 4, half-maximal inhibitory concentration: 3 nM
For compound 4 the middle estimate is 60-fold (1.78 log units) above the measured one, outside the stated range (below it).
By their numbers in this assay, from the lowest: compound 4; then compound 1; then compound 2; then compound 3.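

In this assay, adding a methoxy group to an aromatic carbon, ortho to a methoxy group, gave a 23-fold lower number from compound 1 to compound 4 (1.37 log units; beyond the scatter). Compounds 1, 2 and 3 differ only in the group already on this ring, and both of those listed changes from compound 1 raised the number; compound 4 shows that a ring carbon left bare in all three can hold a methoxy group and that filling it can strengthen inhibition substantially. Nothing shown here explains why this added group has so large an effect.

With methoxy as the only group shown at this position, it remains open whether a hydroxyl group, a fluorine atom, an amine or a longer chain such as propoxy would give a similar result, or whether the gain is particular to methoxy. Going by these compounds, it is also open whether the new methoxy group would have the same effect without the original methoxy group, or with ethoxy or (trifluoromethyl)sulfanyl in its place.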